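Chalcone series: p65 inhibition, methoxy for bromo swap

This account rests on a few compounds, and the source may have more. Where it says the series, first, only, none or still open, it means among the compounds named here.

Measured so far:
compound 1 `COc1cccc(/C=C/C(=O)c2cccc(-c3cccc(F)c3)c2)c1OC` — 24100 nM
compound 2 `O=C(/C=C/c1cccc(Br)c1)c1cccc(-c2cccc(F)c2)c1` — 11200 nM

In an assay on A549 cells for inhibition of transcription factor p65 (Homo sapiens), read by fluorescence, with a stated time of 2 h (on this read-out lower numbers stand for stronger inhibition and higher numbers for weaker inhibition), compound 2 gives 11200 nM and compound 1 gives 24100 nM. Compound 2 therefore has the lowest number of the two measured, and its gap to compound 1 lies beyond the usual scatter of the assay. Among the measured compounds shown here, the two measured compounds differ from each other in more than one place, so their pair yields no single isolated step and no direction can be read off for any one change.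

Compound 3 `COc1ccc(/C=C/C(=O)c2cccc(-c3cccc(F)c3)c2)cc1` is not yet measured. It differs from compound 2 in one place: 4-methoxyphenyl in place of 3-bromophenyl on a double-bonded chain carbon bound to a double-bonded chain carbon. For the measured compounds named here, no measured pair shows this change. Going by the values given here, the only guide is that compound 1, which carries methoxy groups on the same ring, gives 24100 nM, a higher number than compound 2.

For compound 3 a step from compound 2 in this assay of a 1.8-fold higher number from compound 2 to compound 3 (0.25 log units; within the scatter) is expected, towards a higher number. Compound 3 is estimated at 20000 nM, within a range of 8000 nM to 50000 nM.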

Compound 3, half-maximal inhibitory concentration: > 50000 nM
Compound 3 was reported as a limit (the forecaster's own chance of this, stated with the estimate: 15%); middle value at least 2.5-fold (0.39 log units) away from the limit.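

In this assay, among the compounds shown here, 4-methoxyphenyl in place of 3-bromophenyl on a double-bonded chain carbon bound to a double-bonded chain carbon gives the first isolated step: an at least 4.4-fold higher number from compound 2 to compound 3 (0.64 log units; beyond the scatter). The value of compound 3 is a limit and not a number, so this step is bounded on one side only: the limit of > 50000 nM in this assay, at which 1 of the 3 values shown sits.

Even so, the step shows that the group at this place alone can move the read-out beyond the scatter, which the earlier pair could not show, since compound 1 and compound 2 differ in more than one place.

The compounds shown do not separate the exchange of bromine for methoxy from the difference in ring location carried by the two group names, so neither part of the change can be credited with the step on its own. Also open, as far as these compounds go, is whether a phenyl ring bearing an amine or a carboxylic acid at this place would give a lower number than compound 2, and how far any such group would carry across the series.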